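The compounds below may be only part of what the source reports. "The series", "measured", "known", "first", "only" and "open" are said of these compounds alone.

Measured in an assay on HEK293 cells for binding affinity to corticotropin-releasing factor receptor 1 (Homo sapiens); on this read-out higher numbers stand for weaker inhibition and lower numbers for stronger inhibition:
- compound 1 `CCN(CC)c1nc(C)nc2c1sc(=S)n2-c1ccc(C(C)C)cc1Br`: 4.1 nM
- compound 2 `CCCN(CC1CC1)c1nc(C)nc2c1sc(=S)n2-c1ccc(C(C)C)cc1Br`: 12.6 nM
- compound 3 `CCCCN(CC)c1nc(C)nc2c1sc(=S)n2-c1ccc(C(C)C)cc1Br`: 23.9 nM

Compound 3 stands at the highest number of the three in this assay. Its gap to compound 2 is within the scatter, a 1.9-fold higher number from compound 2 to compound 3 (0.28 log units; within the scatter), while its gap to compound 1 is beyond it, a 5.8-fold higher number from compound 1 to compound 3 (0.77 log units; beyond the scatter).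

Compound 4 `CCC(C)N(c1nc(C)nc2c1sc(=S)n2-c1ccc(C(C)C)cc1Br)C(C)CC` differs from compound 3 in one place: bis(sec-butyl)amino in place of butyl(ethyl)amino on an aromatic carbon. Among the compounds with values here, the change replaces one larger amino group by another, and the only steps that bear on it are the two departures from the diethylamino group of compound 1, a 3.1-fold higher number from compound 1 to compound 2 (0.49 log units; beyond the scatter) and a 5.8-fold higher number from compound 1 to compound 3 (0.77 log units; beyond the scatter), both of which raised the number in this assay. Between the two enlarged amino groups, however, the step of a 1.9-fold higher number from compound 2 to compound 3 (0.28 log units; within the scatter) stayed within the scatter. Within the data shown here, there is no measured example of branching at both chains on this nitrogen, so the expectation rests on the direction of the enlargement steps alone. A further rise in the number of compound 4 is expected, of modest size, with a real chance that it stays within the scatter of compound 3. Compound 4 is expected at 45 nM, with a range from 15 nM to 140 nM. The expected step is a 1.9-fold higher number from compound 3 to compound 4 (0.27 log units; within the scatter).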

Compound 4, inhibition constant: 45.4 nM
Beside the measured number, compound 4's estimate is 1.0-fold (0.00 log units) below it, within the range that was stated.
By their numbers in this assay, from the lowest: compound 1; then compounds 2, 3 and 4 (each within the scatter of the next, the first and the last beyond it).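

In this assay, the step from butyl(ethyl)amino to bis(sec-butyl)amino, a 1.9-fold higher number from compound 3 to compound 4 (0.28 log units; within the scatter), shows that a group branched on both chains at this aromatic carbon cannot be told apart from the unbranched butyl(ethyl)amino of compound 3. Set against the other two amino groups, the same group does separate, with a 3.6-fold higher number from compound 2 to compound 4 (0.56 log units; beyond the scatter) and an 11-fold higher number from compound 1 to compound 4 (1.04 log units; beyond the scatter), the latter the only large step in the series; all three enlarged groups now lie beyond the scatter of the diethylamino group of compound 1, which holds the lowest number of the four. Nothing measured alongside these numbers offers an explanation for the steps.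

The compounds shown leave open whether the number at this position follows branching, chain length or total group size, since these vary together among the four amino groups. Also open, going by these compounds, is how dimethylamino, or a cyclic amine such as morpholine, would read at this carbon against the diethylamino group of compound 1.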